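Three Sulfonamides at the Limit and a Chloro Variant

A few compounds are considered here, and "the series" means these few. Any claim that something is new, unique, unknown or untested is made for them only; others in the source may bear on it.

Compound 1 `Cc1cc(C)c(S(=O)(=O)NC2=NCCN2C(=S)SN2CCn3c2nsc3=S)c(C)c1`: in a functional assay on KYSE-510 cells (Homo sapiens) for antiproliferative activity, read by crystal violet staining, with a stated time of 96 h (a higher number here means a weaker inhibitor of growth, a lower number a stronger inhibitor of growth), compound 1 gives >= 20000 nM, which is a limit of the assay and not a number.
Compound 2 `COc1ccc(S(=O)(=O)NC2=NCCN2C(=S)SN2CCn3c2nsc3=S)cc1OC`: in this assay compound 2 gives >= 20000 nM, likewise a limit.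
Compound 3 `O=S(=O)(NC1=NCCN1C(=S)SN1CCn2c1nsc2=S)c1cccc(OC(F)(F)F)c1`: in this assay compound 3 gives >= 20000 nM, again a limit.

Compound 3 thus stands at the same limit as the other two, (the limit of >= 20000 nM in this assay, at which 3 of the 3 values shown sit), so no order among the three can be read. Among the measured compounds shown here, the only one-place step, a step that the two limits leave unreadable from compound 1 to compound 2, cannot be sized: both its ends are limits. Compound 4 `O=S(=O)(NC1=NCCN1C(=S)SN1CCn2c1nsc2=S)c1cccc(Cl)c1` differs from compound 3 by chloro in place of trifluoromethoxy on an aromatic carbon. For the measured compounds named here, no measured step bears on this change, and every value so far sits at the limit. Compound 4 is therefore expected to remain a weak inhibitor, with an estimated step that the limit leaves unreadable from compound 3 to compound 4. Compound 4 is estimated at 25000 nM in this assay, within 8000 nM to 80000 nM.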

Compound 4, concentration for 50% growth inhibition: >= 20000 nM
Compound 4 gave a limit, no number; the forecaster's own chance of this, stated with the estimate: 85%; the middle value does not contradict the limit.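

Compound 4 sits at the same limit as compound 1, compound 2 and compound 3, so no step among them can be read: the limit of >= 20000 nM in this assay, at which 4 of the 4 values shown sit.

The compounds shown leave open which group on the sulfonyl sulfur, if any, would give a readable number in this assay.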